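The source may hold more compounds than are shown below. What is called first, only, known or untested is meant among the compounds shown, and "the series" means these compounds.

Measured compounds:
compound 1, `Cc1nn(-c2ccccc2)c2nc(-c3ccccc3)c(C#N)c(-c3ccccc3O)c12`, in an ADME assay on BJ cells (Homo sapiens) for cytotoxicity, with a stated time of 72 h (on this read-out higher numbers stand for an effect only at larger amounts of compound and lower numbers for an effect already at smaller amounts), gives > 23000 nM
compound 2, `CCc1ccc(-c2nc3c(c(C)nn3-c3ccccc3)c(-c3ccccc3C#N)c2C#N)cc1`, in this assay gives > 20000 nM

Compound 2 stands at the edge of what this assay can report: its value is a limit of the assay and not a number, (the limit of > 20000 nM in this assay, at which 1 of the 2 values shown sits). Among the measured compounds shown here, the one other value shown, that of compound 1, is likewise a limit and not a number, (the limit of > 23000 nM in this assay, at which 1 of the 2 values shown sits). Neither measured value therefore fixes where compound 2 sits, only that it sits at or beyond the limit.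

Compound 3, `CCc1ccc(-c2nc3c(c(C)nn3-c3ccccc3)c(-c3ccccc3S(C)(=O)=O)c2C#N)cc1`, differs from compound 2 in a single place: methylsulfonyl in place of cyano on an aromatic carbon.

For the measured compounds named here, no step between measured compounds is available, so there is nothing to carry over. The step that the limit leaves unreadable from compound 2 to compound 3 is expected to be none beyond the scatter, in no particular direction. Compound 3 is accordingly expected to give about 25000 nM, within a range from 8000 nM to 80000 nM, and most probably to be reported only as a limit.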

Compound 3, half-maximal effective concentration: > 20000 nM
Compound 3: no number, only a limit; the forecaster's own chance of this, stated with the estimate: 85%; the middle value is on the limit's open side.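

Among the compounds shown here, compound 2 and compound 3 are both reported only as limits in this assay, so no step between them can be read. The compounds shown leave open how far either lies beyond its limit, and whether methylsulfonyl in place of cyano changes the read-out at all.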